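Swapping the Saturated Amine on the Amide Side Chain

A few compounds are considered here, and "the series" means these few. Any claim that something is new, unique, unknown or untested is made for them only; others in the source may bear on it.

The series shares one core, shown in compound 1 `CC1=NN(C(=O)c2ccc(C)cc2)C(c2ccccc2O)C1`, and varies the group on the carbonyl carbon. In a functional assay on PC-3 cells (Homo sapiens) for cytotoxicity, read by MTT assay, with a stated time of 48 h (a lower number here means a stronger inhibitor, a higher number a weaker inhibitor), compound 1 gives 40600 nM. Compound 2 `CC1=NN(C(=O)CN2CCCCC2)C(c2ccccc2O)C1` gives 5890 nM, and compound 3 `CC1=NN(C(=O)CN2CCCC2)C(c2ccccc2O)C1` gives 6670 nM. Compound 3 thus stands second highest of the three numbers: its nearest neighbour is compound 2, since a 1.1-fold higher number from compound 2 to compound 3 (0.05 log units; within the scatter); its furthest is compound 1, since a 6.1-fold lower number from compound 1 to compound 3 (0.78 log units; beyond the scatter). The parallel step a 6.9-fold lower number from compound 1 to compound 2 (0.84 log units; beyond the scatter) shows the same modest gain on moving from the aryl group to a saturated amine on the chain carbon.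

Compound 4 `CC1=NN(C(=O)CN2CCN(C)CC2)C(c2ccccc2O)C1` continues from compound 3 by the change (4-methylpiperazin-1-yl in place of pyrrolidin-1-yl on a saturated chain carbon bound to a carbonyl carbon). For the measured compounds named here, the one measured step that bears on this exchange is the swap between two saturated amines on the same chain carbon, and there a 1.1-fold higher number from compound 2 to compound 3 (0.05 log units; within the scatter) remained within the scatter. No other comparison among the measured compounds speaks to a second ring nitrogen or to its methyl group. Compound 4 is therefore expected to give 6000 nM, with a range of 2500 nM to 14000 nM, and the expected step of a 1.1-fold lower number from compound 3 to compound 4 (0.05 log units; within the scatter) is one that would not clearly exceed the scatter.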

Compound 4, half-maximal inhibitory concentration: 11800 nM
Estimate against measurement, compound 4: 2.0-fold (0.29 log units) below; low and high end bracket the measured number.
By their numbers in this assay, from the lowest: compounds 2, 3 and 4 (each within the scatter of the next); then compound 1.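

In this assay, for the compounds shown here, placing 4-methylpiperazin-1-yl on the saturated chain carbon bound to a carbonyl carbon, the first group with 2 hetero atoms in its ring, gives a 1.8-fold higher number from compound 3 to compound 4 (0.25 log units; within the scatter), and set against piperidin-1-yl it gives a 2.0-fold higher number from compound 2 to compound 4 (0.30 log units; within the scatter). Both steps lie within the scatter, so this position takes a saturated amine with a second ring nitrogen and a methyl group, and 7 heavy atoms in place of 5, with no measurable separation from the two simpler rings, which extends what the swap between those two rings could show. Nothing measured for these groups gives a reason for these numbers.

The compounds shown leave open whether the second ring nitrogen and its methyl group have separate effects, which an unsubstituted piperazin-1-yl or a morpholin-4-yl with a ring oxygen in place of that nitrogen could help to separate. They also leave open how an open-chain amine such as diethylamino, or a longer chain between the carbonyl and the ring nitrogen, would read in this assay.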